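The source may report more compounds than this note shows. Statements on the series, on what has been measured and on what is new or still open speak of the compounds shown alone.

Compound 1 `CCC(C)n1ncn(-c2ccc(N3CCN(c4ccc(OC[C@@H]5CO[C@@](Cn6cncn6)(c6ccc(Cl)cc6Cl)O5)nc4)CC3)cc2)c1=O` and compound 3 `CCC(C)n1ncn(-c2ccc(N3CCN(c4ccc(OC[C@@H]5CO[C@@](Cn6ccnc6)(c6ccc(Cl)cc6Cl)O5)nc4)CC3)cc2)c1=O` share a core and differ in one place: 1H-imidazol-1-yl in place of 1H-1,2,4-triazol-1-yl on a saturated chain carbon bound to a saturated ring carbon. In a physicochemical assay for solubility, read by HPLC, measured as thermodynamic solubility (on this read-out lower numbers stand for lower solubility and higher numbers for higher solubility), compound 1 gives 0.116 ug/mL, while compound 3 gives 6.48 ug/mL, so the step is a 56-fold higher number from compound 1 to compound 3 (1.75 log units; beyond the scatter).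

Compound 2 `CCC(C)n1ncn(-c2ccc(N3CCN(c4ccc(OC[C@@H]5CO[C@@](Cn6cncn6)(c6ccc(Cl)cc6Cl)O5)cc4)CC3)c(F)c2)c1=O` is built on a second core; the difference between the two cores is not broken down here. In this assay, among the compounds with values here, compound 2 gives 0.0291 ug/mL, the lowest of the three numbers measured so far, and its gap to compound 1 and to compound 3 lies beyond the scatter of repeated measurements in each case.

Compound 4 `CCC(C)n1ncn(-c2ccc(N3CCN(c4ccc(OC[C@@H]5CO[C@@](Cn6ccnc6)(c6ccc(Cl)cc6Cl)O5)cc4)CC3)c(F)c2)c1=O` stands to compound 2 as compound 3 stands to compound 1. The change is the same: 1H-imidazol-1-yl in place of 1H-1,2,4-triazol-1-yl on a saturated chain carbon bound to a saturated ring carbon. Within the data shown here, only one measured example of this change exists, the pair of compound 1 and compound 3, so the expectation rests on that single step and on the assumption that the second core, in which compound 2 sits, carries it in a similar way.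

On that basis compound 4 is expected to show a step of a 52-fold higher number from compound 2 to compound 4 (1.71 log units; beyond the scatter), placed beside the earlier step of a 56-fold higher number from compound 1 to compound 3 (1.75 log units; beyond the scatter) as its model. Among the measured compounds shown here, the estimate for compound 4 in this assay is therefore 1.5 ug/mL, with the likely range running from 0.3 ug/mL to 6 ug/mL, the width reflecting that a single precedent on a different core is the only guide.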

Compound 4, solubility: 17.2 ug/mL
Compound 4: middle estimate off by 11-fold (1.06 log units), on the low side; the whole stated range lies below it.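

In this assay the change from 1H-1,2,4-triazol-1-yl to 1H-imidazol-1-yl goes the same way on both cores, with a 590-fold higher number from compound 2 to compound 4 (2.77 log units; beyond the scatter) on the second core set against a 56-fold higher number from compound 1 to compound 3 (1.75 log units; beyond the scatter) on the first, and the step on the second core is the larger of the two. With only these two pairs, the step on one core gave the right direction on the other but not the right size, and no rule follows for how large the change would be on a further core. Nothing measured here accounts for the difference in size between the two steps.

The compounds shown leave open whether the same change would hold on a third core, and whether a step of this size is particular to 1H-imidazol-1-yl. A 1H-pyrazol-1-yl ring or an open-chain amine such as dimethylamino, placed on a saturated chain carbon bound to a saturated ring carbon, is not among these compounds and would speak to that second question.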